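From iodo to trifluoromethyl in compound 3

This account rests on a few compounds, and the source may have more. Where it says the series, first, only, none or still open, it means among the compounds named here.

Within the data shown here, in a functional assay (strain AB) with Danio rerio as the target, read by microscopy, with a stated time of 1 h (a lower number here means that less compound is needed, a higher number that more compound is needed for the effect), compound 3 `CCN1CCc2c(sc(NC(=O)Nc3ccc(I)cc3)c2C(N)=O)C1` gives 1620 nM, the only number among the three values shown. Compound 1 `CCN1CCc2c(sc(NC(=O)Nc3ccccc3)c2C(N)=O)C1` gives > 25000 nM, which is a limit. Compound 2 `CCN1CCc2c(sc(NC=O)c2C(N)=O)C1` gives > 25000 nM, which is also a limit. The data therefore show a step that the two limits leave unreadable from compound 1 to compound 2, while an at least 15-fold lower number from compound 2 to compound 3 (1.18 log units; beyond the scatter) sets compound 3 clearly apart.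

Compound 4 `CCN1CCc2c(sc(NC(=O)Nc3ccc(C(F)(F)F)cc3)c2C(N)=O)C1` differs from compound 3 in one place: trifluoromethyl in place of iodo on an aromatic carbon. The measured step that bears most directly on this change is an at least 15-fold lower number from compound 1 to compound 3 (1.18 log units; beyond the scatter). With that step as a guide, trifluoromethyl is expected to retain most of what iodo gained, although no second group at this place has been measured. The expected result is a 1.5-fold higher number from compound 3 to compound 4 (0.19 log units; within the scatter), a slightly higher number but no step beyond the scatter. Compound 4 is expected at 2500 nM, with an estimated range from 700 nM to 9000 nM.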

Compound 4, half-maximal effective concentration: 2910 nM
Compound 4: the middle estimate sits 1.2-fold (0.07 log units) below what was measured, and the stated range covers the measured number.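

In this assay, the gain at this position proves not to be tied to iodo: there is a 1.8-fold higher number from compound 3 to compound 4 (0.25 log units; within the scatter), a step within the scatter, so the two groups cannot be told apart here. Trifluoromethyl, on an aromatic carbon para to a large group, also sets its compound clearly apart from the one carrying hydrogen at that place, with an at least 8.5-fold lower number from compound 1 to compound 4 (0.93 log units; beyond the scatter). That size is only a lower bound because compound 1 sits at a limit of the assay: the limit of > 25000 nM in this assay, at which 2 of the 4 values shown sit.

The compounds shown leave open whether an amine, a carboxylic acid or a methoxy group at this place would hold the number in the same range. They also leave open whether iodo or trifluoromethyl on another carbon of the same ring would do so.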